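The compounds below may be only part of what the source reports. "The series", "measured", "known", "first", "only" and "open" are said of these compounds alone.

In a functional assay on Shh Light II cells (Mus musculus) for inhibition, read by a luciferase reporter (a higher number here means a weaker inhibitor, a lower number a stronger inhibitor), three compounds have been measured:
compound 1 `Cc1noc(C)c1NC(=O)N1CCC(c2nc(-c3ccc4ccccc4n3)no2)CC1` gives 3000 nM
compound 2 `N#Cc1ccccc1NC(=O)N1CCC(c2nc(-c3ccc4ccccc4n3)no2)CC1` gives 190 nM
compound 3 `O=C(NC1CCC(O)CC1)N1CCC(c2nc(-c3ccc4ccccc4n3)no2)CC1` gives 2700 nM

Compound 3 holds the second highest of these three numbers; it sits within the scatter of compound 1 (a 1.1-fold lower number from compound 1 to compound 3 (0.05 log units; within the scatter)) and far from compound 2 (a 14-fold higher number from compound 2 to compound 3 (1.15 log units; beyond the scatter)). Compound 4 `O=C(NC1CCOCC1)N1CCC(c2nc(-c3ccc4ccccc4n3)no2)CC1` differs from compound 3 by oxan-4-yl in place of 4-hydroxycyclohexyl on an amide-type nitrogen. Among the compounds with values here, no measured step swaps one saturated six-membered ring for another; the only steps at this amide-type nitrogen are a 16-fold lower number from compound 1 to compound 2 (1.20 log units; beyond the scatter) and a 14-fold higher number from compound 2 to compound 3 (1.15 log units; beyond the scatter), both of which set the 2-cyanophenyl apart from the other two groups. Compound 4 keeps a saturated ring there, so a step within the scatter is expected, a 1.3-fold higher number from compound 3 to compound 4 (0.11 log units; within the scatter). Compound 4 is therefore estimated at 3500 nM, with a range of 1200 nM to 10000 nM.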

Compound 4, half-maximal inhibitory concentration: 480 nM
Beside the measured number, compound 4's estimate is 7.3-fold (0.86 log units) above it; measured number below the stated range.
By their numbers in this assay, from the lowest: compound 2; then compound 4; then compounds 3 and 1 (each within the scatter of the next).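

With oxan-4-yl in place of 4-hydroxycyclohexyl on the amide-type nitrogen, this assay shows that the two saturated six-membered rings do not read alike (a 5.6-fold lower number from compound 3 to compound 4 (0.75 log units; beyond the scatter)). Oxan-4-yl also stands apart from 3,5-dimethyl-1,2-oxazol-4-yl (a 6.3-fold lower number from compound 1 to compound 4 (0.80 log units; beyond the scatter)) while remaining short of 2-cyanophenyl (a 2.5-fold higher number from compound 2 to compound 4 (0.40 log units; beyond the scatter)), so the groups at this nitrogen no longer divide into 2-cyanophenyl against the other groups. No evidence is available to explain the step from 4-hydroxycyclohexyl to oxan-4-yl. As far as these compounds go, whether a plain cyclohexyl or a piperidin-4-yl group would fall with compound 3 or with compound 4 remains open.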